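This account rests on a few compounds, and the source may have more. Where it says the series, first, only, none or still open, it means among the compounds named here.

The measured compounds are these.
Compound 1, `Cc1ccc(Nc2nc(Cl)nc3c2ncn3Cc2ccc(C(=O)Nc3ccccc3N)cc2)cc1`; in a functional assay on NCI-H460 cells (Homo sapiens) for antiproliferative activity, read by CCK-8 assay, with a stated time of 72 h, tested at 2 uM (on this read-out higher numbers stand for a stronger effect at the one concentration tested and lower numbers for a weaker effect), compound 1 gives 67.3%.
Compound 2, `CC1CCN(c2nc(Cl)nc3c2ncn3Cc2ccc(/C=C/C(=O)Nc3ccccc3N)cc2)CC1`; in this assay compound 2 gives 8.24%.
Compound 3, `Cc1ccc(Nc2nc(Cl)nc3c2ncn3Cc2ccc(/C=C/C(=O)Nc3ccccc3N)cc2)cc1`; in this assay compound 3 gives 31.3%.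

Compound 3 holds the second highest of the three numbers. Its nearest neighbour is reached by the step of a number 23.1 percentage points higher from compound 2 to compound 3 (beyond the scatter), its furthest by the step of a number 36 percentage points lower from compound 1 to compound 3 (beyond the scatter). Compound 4, `Nc1ccccc1NC(=O)/C=C/c1ccc(Cn2cnc3c(Nc4cccc(Cl)c4)nc(Cl)nc32)cc1`, differs from compound 3 in one place: 3-chlorophenyl in place of 4-methylphenyl on a nitrogen on an aromatic ring. Neither measured step touches that place. Among the compounds with values here, the step of a number 36 percentage points lower from compound 1 to compound 3 (beyond the scatter) concerns the 2-((2-aminophenyl)carbamoyl)ethenyl group, and the step of a number 23.1 percentage points higher from compound 2 to compound 3 (beyond the scatter) replaces the whole 4-methylpiperidin-1-yl with (4-methylphenyl)amino, so it shows only that an arylamino group at that aromatic carbon gives the higher number, not how one aryl compares with another. Within the data shown here, with no step that bears on a change from 4-methylphenyl to 3-chlorophenyl, the expected step in this assay is none beyond the scatter, in either direction. The estimated step is therefore a number 1.7 percentage points higher from compound 3 to compound 4 (within the scatter). Compound 4 is expected to give about 33%, within a range from 14% to 56%.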

Compound 4, a percentage reported as inhibition, at one concentration (the size of the read-out at that concentration, not a potency): 7.11%
For compound 4 the middle estimate is 25.9 percentage points above the measured one; measured number outside the range, below it.
By their numbers in this assay, from the lowest: compounds 4 and 2 (each within the scatter of the next); then compound 3; then compound 1.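

In this assay, the change from 4-methylphenyl to 3-chlorophenyl on the nitrogen gives a number 24.2 percentage points lower from compound 3 to compound 4 (beyond the scatter) and so shows that the number depends on which aryl group is present, not only on having an arylamino group on that aromatic carbon. With (3-chlorophenyl)amino in place of 4-methylpiperidin-1-yl, the result is a number 1.1 percentage points lower from compound 2 to compound 4 (within the scatter) and so the gain seen with (4-methylphenyl)amino over 4-methylpiperidin-1-yl does not extend to this second aryl group. Nothing available here explains the difference between the two aryl groups.

The compounds shown do not separate the loss of the methyl from the arrival of the chlorine, and they leave open how 3-methylphenyl, 4-chlorophenyl or unsubstituted phenyl would compare. From the compounds shown here alone, it also remains open whether 3-chlorophenyl would have the same effect with the (2-aminophenyl)carbamoyl group of compound 1 in place of the 2-((2-aminophenyl)carbamoyl)ethenyl group.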